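Shortening the amine substituent at the shared core

The source may report more compounds than this note shows. Statements on the series, on what has been measured and on what is new or still open speak of the compounds shown alone.

Compound 2 `CCC(C)[C@H](NCC1CCCO1)c1cc(C(F)(F)F)ccc1N1CCN(C(=O)CCc2ccc(Cl)cc2Cl)CC1` holds the lower of the two numbers measured in an assay on HEK293 cells for displacement of a labelled ligand from Melanocortin receptor 4 (Homo sapiens); on this read-out higher numbers stand for weaker inhibition and lower numbers for stronger inhibition: compound 2 gives 780 nM, while compound 1 `CCC(C)CN[C@H](c1cc(C(F)(F)F)ccc1N1CCN(C(=O)CCc2ccc(Cl)cc2Cl)CC1)C(C)CC` gives 2800 nM. For the measured compounds named here, the single measured step between them, a 3.6-fold lower number from compound 1 to compound 2 (0.56 log units; beyond the scatter), is the only guide to how this part of the shared core responds to change.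

Compound 3 `CN[C@@H](CC(C)C)c1cc(C(F)(F)F)ccc1N1CCN(C(=O)CCc2ccc(Cl)cc2Cl)CC1` differs from compound 2 by 3-methyl-1-(methylamino)butyl in place of 2-methyl-1-(((oxolan-2-yl)methyl)amino)butyl on an aromatic carbon. Going by the values given here, the group that enters carries no ring and a methyl on the amine nitrogen, so the change goes in the direction opposite to the one step known, in which the oxolan-2-yl unit in place of sec-butyl lowered the number by a 3.6-fold lower number from compound 1 to compound 2 (0.56 log units; beyond the scatter). That step bears on compound 3 only loosely, since the chain on the carbon also shifts from 2-methylbutyl to 3-methylbutyl, for which no comparison exists.

Compound 3 is therefore expected to return a higher number than compound 2, by roughly a 3.2-fold higher number from compound 2 to compound 3 (0.51 log units; beyond the scatter). The estimate for compound 3 in this assay is 2500 nM, within a range from 800 nM to 8000 nM.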

Compound 3, inhibition constant: 1900 nM
Estimate against measurement, compound 3: 1.3-fold (0.12 log units) above; low and high end bracket the measured number.
By their numbers in this assay, from the lowest: compound 2; then compounds 3 and 1 (each within the scatter of the next).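

In this assay, the exchange of 2-methyl-1-(((oxolan-2-yl)methyl)amino)butyl for 3-methyl-1-(methylamino)butyl on this aromatic carbon gives a 2.4-fold higher number from compound 2 to compound 3 (0.39 log units; beyond the scatter) and leaves compound 2 with the lowest number of the three, its steps to both other compounds lying beyond the scatter. The comparison of the two groups without a ring, 2-methyl-1-((2-methylbutyl)amino)butyl and 3-methyl-1-(methylamino)butyl, gives a 1.5-fold lower number from compound 1 to compound 3 (0.17 log units; within the scatter) and so separates neither from the other, which means that among these three compounds only the group carrying the oxolan-2-yl ring stands apart. Nothing available accounts for these differences.

Since the step to compound 3 alters both the substituent on the amine nitrogen and the branching of the chain, the share of each in the result stays unresolved, and only a methyl on the nitrogen paired with the 2-methylbutyl chain, or the (oxolan-2-yl)methyl group paired with the 3-methylbutyl chain, would divide it. From the compounds shown here alone, it also remains open whether the ring oxygen matters, which a cyclopentylmethyl group on the nitrogen would test, and how a primary amine would read at this position.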